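This account rests on a few compounds, and the source may have more. Where it says the series, first, only, none or still open, it means among the compounds named here.

Two analogues of the shared core have been run in an assay on Sf9 cells for inhibition of protein deacetylase HDAC6 (Homo sapiens), read by fluorescence, with a stated time of 40 min, tested at 100 nM; a lower number here means less inhibition, a higher number more inhibition at the concentration tested (going by the name of the read-out). Compound 1 `CCc1ccc(-c2nc(CNc3ccc(C(=O)NO)cc3)n(-c3ccccc3)n2)cc1` gives 54.6%, and compound 2 `Cc1cccc(-c2nc(CNc3ccc(C(=O)NO)cc3)n(-c3ccccc3)n2)c1` gives 64.1%. Within the data shown here, on paper compound 2 sits at the top of this pair, but the only step so far, a number 9.5 percentage points higher from compound 1 to compound 2 (within the scatter), is within the scatter, so the two numbers cannot be told apart. Compound 3 `O=C(NO)c1ccc(NCc2nc(-c3ccc(C(F)(F)F)cc3)nn2-c2ccccc2)cc1` is not yet measured. It differs from compound 2 by 4-(trifluoromethyl)phenyl in place of 3-methylphenyl on an aromatic carbon. Among the measured compounds shown here, the one measured step that bears on this, a change of the group on that same aromatic carbon, is a number 9.5 percentage points higher from compound 1 to compound 2 (within the scatter), within the scatter; nothing measured says that a further change of that group should move the read-out beyond it. The expected step of a number 4.1 percentage points lower from compound 2 to compound 3 (within the scatter) is therefore none beyond the scatter. Compound 3 is estimated at 60% in this assay, with a range from 42% to 78%.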

Compound 3, a percentage reported as inhibition, at one concentration (the size of the read-out at that concentration, not a potency): 41.6%
Beside the measured number, compound 3's estimate is 18.4 percentage points above it; the whole stated range lies above it.
By their numbers in this assay, from the lowest: compound 3; then compounds 1 and 2 (each within the scatter of the next).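

The aryl group on the aromatic carbon between two ring nitrogen atoms now shows an effect in this assay that lies beyond the scatter, with 4-(trifluoromethyl)phenyl in place of 3-methylphenyl giving a number 22.5 percentage points lower from compound 2 to compound 3 (beyond the scatter). Trifluoromethyl in place of ethyl changes only the group on the phenyl ring and gives a number 13 percentage points lower from compound 1 to compound 3 (beyond the scatter), so the lower number for compound 3 holds against both earlier compounds. No measurement at hand accounts for either step.

From the compounds shown here alone, it remains open whether the lower number is specific to trifluoromethyl or extends to other groups on that phenyl ring, such as chlorine, methoxy or a nitrile. An unsubstituted phenyl or a pyridine ring at this place would show whether any substituent on the aryl group is needed for the inhibition seen in this assay.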